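A few compounds are considered here, and "the series" means these few. Any claim that something is new, unique, unknown or untested is made for them only; others in the source may bear on it.

Compound 3 `COc1cc(Nc2ncccc2-c2n[nH]c(Nc3ccc4c(c3)OCCO4)n2)cc(OC)c1` stands highest of the two numbers available in a functional assay on A-431 cells (Homo sapiens), tested at 0.1 uM (a higher number here means more inhibition at the concentration tested (going by the name of the read-out), a lower number less inhibition), where compound 3 gives 83%. Compound 1 `COc1cc(Nc2ncccc2-c2n[nH]c(Nc3ccccc3)n2)cc(OC)c1` gives 22% in this assay, and for compound 2 `COc1cc(Nc2ncccc2-c2n[nH]c(Nc3ccc(C#N)cc3)n2)cc(OC)c1` the result in this assay is "not determined" (no result reported). For the measured compounds named here, the single measured step, a number 61 percentage points higher from compound 1 to compound 3 (beyond the scatter), concerns the group on a nitrogen on an aromatic ring and is large. Compound 4 `COc1cc(Nc2ncccc2-c2nc(Nc3ccc4c(c3)OCCO4)n(C)n2)cc(OC)c1` differs from compound 3 by methyl in place of hydrogen on an aromatic nitrogen. Going by the values given here, no measured step touches this kind of change, so neither its direction nor its size can be read from the set, and the one large step seen gives no guide here. The estimate for compound 4 in this assay is 45%, with a range from 10% to 85%. This expected value amounts to a step of a number 38 percentage points lower from compound 3 to compound 4 (beyond the scatter), most likely downward but with wide uncertainty.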

Compound 4, a percentage reported as inhibition, at one concentration (the size of the read-out at that concentration, not a potency): 26%
Compound 4: the middle estimate sits 19 percentage points above what was measured; the measured number falls inside the stated range.
By their numbers in this assay, from the lowest: compounds 1 and 4 (each within the scatter of the next); then compound 3.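

In this assay, for the compounds shown here, methyl in place of hydrogen on the aromatic nitrogen gives a number 57 percentage points lower from compound 3 to compound 4 (beyond the scatter), the first reading at this position. A single added carbon here is enough for a large step, and the number in this assay is lower while the (2,3-dihydro-1,4-benzodioxin-6-yl)amino group stays in place. Nothing available bears on the cause of this drop. Open, from the compounds shown here alone, is whether an ethyl group or a longer chain ending in a hydroxyl on this nitrogen would behave like methyl. Also open, going by these compounds, is whether methyl has the same effect with the phenyl group of compound 1.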